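Trifluoromethyl to chloro on the urea aryl ring

The source may hold more compounds than are shown below. What is called first, only, known or untested is meant among the compounds shown, and "the series" means these compounds.

Measured compounds:
compound 1, `COc1cc2cc(Oc3ccc(NC(=O)Nc4cccc(C(F)(F)F)c4)cc3)c(C)nc2cc1OC`, 1740 nM in a functional assay on 786-0 cells (Homo sapiens) for inhibition, read by sulforhodamine B assay, with a stated time of 48 h; a higher number here means a weaker inhibitor of growth, a lower number a stronger inhibitor of growth
compound 2, `COc1cc2cc(Oc3ccc(NC(=O)Nc4ccc(Cl)c(C(F)(F)F)c4)cc3)c(C)nc2cc1OC`, 1170 nM in this assay

Compound 2 is separated from compound 1 only by a 1.5-fold lower number from compound 1 to compound 2 (0.17 log units; within the scatter), a step within the scatter, so the two cannot be ranked. Compound 3, `COc1cc2cc(Oc3ccc(NC(=O)Nc4ccc(Cl)c(Cl)c4)cc3)c(C)nc2cc1OC`, differs from compound 2 by chloro in place of trifluoromethyl on an aromatic carbon. For the measured compounds named here, no measured step changes this group; the only step known, chloro replacing hydrogen on an aromatic carbon, was small. A change of comparable size is therefore expected in this assay, a 1.3-fold higher number from compound 2 to compound 3 (0.11 log units; within the scatter), with no clear direction. Compound 3 is expected to give 1500 nM, within 600 nM to 4000 nM.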

Compound 3, concentration for 50% growth inhibition: 3640 nM
Estimate against measurement, compound 3: 2.4-fold (0.39 log units) below, within the range that was stated.
By their numbers in this assay, from the lowest: compounds 2 and 1 (each within the scatter of the next); then compound 3.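

In this assay, for the compounds shown here, this ring carbon, ortho to a chloro group, proves sensitive to the change from trifluoromethyl to chloro, which gives the first step beyond the scatter (a 3.1-fold higher number from compound 2 to compound 3 (0.49 log units; beyond the scatter)). The 3,4-dichlorophenyl group also compares unfavourably with the 3-(trifluoromethyl)phenyl group (a 2.1-fold higher number from compound 1 to compound 3 (0.32 log units; beyond the scatter)), so both steps run towards weaker growth inhibition. Nothing available explains this loss. Still open, going by these compounds, is whether a methyl, bromo or nitrile group on this carbon would match trifluoromethyl, and whether the same change behaves alike without the neighbouring chloro group.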